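Cyclopentyl to Isopropyl: Expected Effect on Cell Growth Inhibition

A few compounds are considered here, and "the series" means these few. Any claim that something is new, unique, unknown or untested is made for them only; others in the source may bear on it.

Three compounds have been measured in a functional assay on HCT-116 cells (Homo sapiens) for antiproliferative activity, read by MTT assay; a lower number here means a stronger inhibitor, a higher number a weaker inhibitor:
Compound 1 `CN1CCN(c2ccc(Nc3ncc(/N=C/c4ccccc4)c(NC4CCCC4)n3)cc2)CC1` gives 35200 nM.
Compound 2 `CN1CCN(c2ccc(Nc3ncc(/N=C/c4ccc(C(F)(F)F)cc4)c(NC4CCCC4)n3)cc2)CC1` gives > 100000 nM, which is a limit of the assay rather than a number.
Compound 3 `NS(=O)(=O)c1ccc(Nc2ncc(/N=C/c3ccccc3)c(NC3CCCC3)n2)cc1` gives 26100 nM.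

Among the two numbers given, compound 1 holds the higher one, with compound 3 nearest; the step of a 1.3-fold lower number from compound 1 to compound 3 (0.13 log units; within the scatter) lies within the scatter, so the two cannot be ranked. For compound 2 only a limit is known: the limit of > 100000 nM in this assay, at which 1 of the 3 values shown sits. The step of an at least 2.8-fold higher number from compound 1 to compound 2 (0.45 log units; beyond the scatter) is therefore beyond the scatter in the direction of weaker inhibition.

Compound 4 `CC(C)Nc1nc(Nc2ccc(N3CCN(C)CC3)cc2)ncc1/N=C/c1ccccc1` differs from compound 1 by isopropyl in place of cyclopentyl on a nitrogen on an aromatic ring. Among the compounds with values here, neither measured step touches this nitrogen; both alter groups on aromatic carbons elsewhere, so no measured step bears directly on the change. With no guide, the expectation for compound 4 is a step within the scatter, a 1.3-fold higher number from compound 1 to compound 4 (0.11 log units; within the scatter), giving an estimate of 45000 nM, between 15000 nM and 150000 nM.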

Compound 4, half-maximal inhibitory concentration: > 100000 nM
Compound 4: no number, only a limit; the forecaster's own chance of this, stated with the estimate: 20%; middle value at least 2.2-fold (0.34 log units) from the limit.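

Within the data shown here, changing the group on this nitrogen is not a neutral swap in this assay, as the first measured step at this position shows: the result is an at least 2.8-fold higher number from compound 1 to compound 4 (0.45 log units; beyond the scatter). For compound 4, the value > 100000 nM is a limit of the assay and not a number, so the step gives only the smallest size the change can have. Isopropyl, which has no ring, therefore gives weaker inhibition than cyclopentyl in this one pair, and compound 4 joins compound 2 at the limit: the limit of > 100000 nM in this assay, at which 2 of the 4 values shown sit.

Still open, going by these compounds, is whether a different group on this nitrogen, such as cyclohexyl or a longer chain like n-butyl, would match or improve on compound 1. Also open, on these data alone, is whether the same swap would have a similar effect on compound 3, which carries sulfamoyl in place of 4-methylpiperazin-1-yl.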